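A few compounds are considered here, and "the series" means these few. Any claim that something is new, unique, unknown or untested is made for them only; others in the source may bear on it.

Compound 3 `COc1ccc(C(=O)/C=C/c2cc(-c3cc(OC)c(OC)c(OC)c3)n[nH]2)cc1OC` gives 1490 nM in a functional assay on UACC-257 cells (Homo sapiens) for inhibition, read by sulforhodamine B assay, with a stated time of 48 h (on this read-out higher numbers stand for weaker inhibition of growth and lower numbers for stronger inhibition of growth), the lowest of the three numbers, though its gap to compound 1 `COc1cc(-c2cc(/C=C/C(=O)c3ccc(N)cc3)[nH]n2)cc(OC)c1OC`, which gives 1870 nM, is within the scatter; compound 2 `COc1cc(-c2cc(/C=C/C(=O)c3ccc(Cl)c(Cl)c3)[nH]n2)cc(OC)c1OC` gives 16300 nM. Compound 4 `COc1ccc(C(=O)/C=C/c2cc(-c3cc(OC)c(OC)c(OC)c3)n[nH]2)cc1` differs from compound 3 by hydrogen in place of methoxy on an aromatic carbon. Among the compounds with values here, no measured step removes a single methoxy; the comparisons at hand swap the whole aryl group on the carbonyl carbon: a 1.3-fold lower number from compound 1 to compound 3 (0.10 log units; within the scatter), an 11-fold lower number from compound 2 to compound 3 (1.04 log units; beyond the scatter) and an 8.7-fold higher number from compound 1 to compound 2 (0.94 log units; beyond the scatter). The dimethoxy and amino variants sit together in this assay, so for compound 4 only a small change is expected, a 1.7-fold higher number from compound 3 to compound 4 (0.22 log units; within the scatter). Compound 4 is therefore estimated at 2500 nM, with a range of 900 nM to 7000 nM.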

Compound 4, concentration for 50% growth inhibition: 1750 nM
Beside the measured number, compound 4's estimate is 1.4-fold (0.15 log units) above it; measured number inside the range.
By their numbers in this assay, from the lowest: compounds 3, 4 and 1 (each within the scatter of the next); then compound 2.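

Within this assay the single-group step a 1.2-fold higher number from compound 3 to compound 4 (0.07 log units; within the scatter) shows that hydrogen in place of methoxy at this place on the ring leaves the read-out within the scatter. Methoxy in place of amino gives a 1.1-fold lower number from compound 1 to compound 4 (0.03 log units; within the scatter) and so adds no separation, while the step of a 9.3-fold lower number from compound 2 to compound 4 (0.97 log units; beyond the scatter) leaves the 3,4-dichlorophenyl variant alone at the weak end of the series. No measured evidence bears on why these numbers fall as they do.

Open, from the compounds shown here alone, is whether a hydroxy group or an ethoxy group at this place stays with compound 3 and compound 4. Also open, going by these compounds, is whether a phenyl group with no substituent does the same.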